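This account rests on a few compounds, and the source may have more. Where it says the series, first, only, none or still open, it means among the compounds named here.

Compound 1 `Cc1cccc(C)c1-c1cccc(COc2ccc(S(=O)(=O)CC(=O)O)cc2)c1` gives 66.1 nM in a functional assay on CHO cells for agonist activity at Free fatty acid receptor 1 (Homo sapiens), read by FLIPR and calcium flux (a lower number here means that less compound is needed, a higher number that more compound is needed for the effect), and holds the lowest of the two numbers; compound 2 `CCCOc1cc(C)c(-c2cccc(COc3ccc(S(=O)(=O)CC(=O)O)cc3)c2)c(C)c1` gives 69.2 nM, and the step of a 1.0-fold higher number from compound 1 to compound 2 (0.02 log units; within the scatter) keeps the two within the scatter. Compound 3 `O=C(O)CS(=O)(=O)c1ccc(OCc2cccc(Oc3ccccc3)c2)cc1` differs from compound 1 by phenoxy in place of 2,6-dimethylphenyl on an aromatic carbon. Among the measured compounds shown here, the only measured step, from compound 1 to compound 2, concerns the propoxy group and does not bear on this exchange, so no measured step guides the expectation and the range is wide. For compound 3 the estimate is 300 nM (range 70 nM to 1500 nM) in this assay. This estimate means an expected step of a 4.5-fold higher number from compound 1 to compound 3 (0.66 log units; beyond the scatter).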

Compound 3, half-maximal effective concentration: 97.7 nM
Compound 3: the middle estimate sits 3.1-fold (0.49 log units) above what was measured; the range from low to high includes it.
By their numbers in this assay, from the lowest: compounds 1, 2 and 3 (each within the scatter of the next).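

Phenoxy in place of 2,6-dimethylphenyl gives a 1.5-fold higher number from compound 1 to compound 3 (0.17 log units; within the scatter) in this assay, so at this aromatic carbon, meta to a large group, the series tolerates this exchange of the whole ring substituent, whereas the earlier step only added propoxy. Phenoxy brings a hydrogen-bond acceptor that 2,6-dimethylphenyl lacks, yet the two numbers stay within the scatter. Nothing available explains why the two groups read alike.

On these data alone, whether benzyloxy in place of phenoxy holds this level remains open. So does whether an amine or propoxy on the phenoxy ring does.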